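Chloro for methyl on a sulfonamide-bearing benzamide core

A few compounds are considered here, and "the series" means these few. Any claim that something is new, unique, unknown or untested is made for them only; others in the source may bear on it.

Four benzamides sharing one core are compared in a functional assay on the whole organism for inhibition, with Canis familiaris (Canis lupus familiaris) as the target; on this read-out lower numbers stand for an effect already at smaller amounts and higher numbers for an effect only at larger amounts of compound. Compound 1 `CCN1CCCC1CNC(=O)c1cc(N(C)S(C)(=O)=O)c(C)cc1OC` gives 1 mg/kg in this assay. Compound 2 `CCN1CCCC1CNC(=O)c1cc(N(C)S(C)(=O)=O)c(Cl)cc1OC` differs from compound 1 by chloro in place of methyl on an aromatic carbon. In this assay compound 2 gives 0.1 mg/kg, which amounts to a 10-fold lower number from compound 1 to compound 2 (1.00 log units; beyond the scatter). Compound 3 `CCN1CCCC1CNC(=O)c1cc(NS(=O)(=O)NC)c(C)cc1OC` carries a different side group: (methylsulfamoyl)amino in place of methyl(methylsulfonyl)amino on an aromatic carbon. For compound 3 this assay reports only a limit, > 1 mg/kg, which is not a number. This gives a number no lower from compound 1 to compound 3 (the limit leaves the size open), and the limit of > 1 mg/kg in this assay, at which 1 of the 3 values shown sits, leaves the true size of that step open.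

Compound 4 `CCN1CCCC1CNC(=O)c1cc(NS(=O)(=O)NC)c(Cl)cc1OC` has not yet been measured in this assay. It differs from compound 3 by chloro in place of methyl on an aromatic carbon. For the measured compounds named here, the two descriptions of the place agree except that the group ortho to the site is (methylsulfamoyl)amino in compound 3 and methyl(methylsulfonyl)amino in compound 1, so the change from compound 3 to compound 4 is the same kind of change as the one from compound 1 to compound 2, not the same change.

Going by the values given here, the step from compound 3 to compound 4 is expected to be an at least 2.0-fold lower number from compound 3 to compound 4 (0.30 log units; that floor lies within the scatter), resting on a 10-fold lower number from compound 1 to compound 2 (1.00 log units; beyond the scatter) as the only measured example of this kind of change. Since compound 3 is known only as a limit, the starting point is uncertain, and compound 4 is estimated to give about 0.5 mg/kg, within roughly 0.1 mg/kg to 3 mg/kg.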

Compound 4, dose for half-maximal effect: > 1 mg/kg
Compound 4: no number, only a limit (the forecaster's own chance of this, stated with the estimate: 30%); middle value at least 2.0-fold (0.30 log units) from the limit.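

Replacing methyl(methylsulfonyl)amino with (methylsulfamoyl)amino on the chloro-bearing core gives an at least 10-fold higher number from compound 2 to compound 4 (1.00 log units; beyond the scatter) in this assay, a step that rests on a limit for compound 4 rather than on a number. Setting this step beside the same replacement on the methyl-bearing core gives the following comparison: the same change on two cores in this assay, a number no lower (the limit leaves the size open) from compound 1 to compound 3 and an at least 10-fold higher number (1.00 log units; beyond the scatter) from compound 2 to compound 4; the limit leaves it open whether they differ. This shows that the replacement gives no lower number on either core, so its direction carries over, but it does not show whether its size does, and the steps between the two limits or involving compound 3 cannot be read exactly, including whether chloro for methyl helps on the (methylsulfamoyl)amino core as it does in a 10-fold lower number from compound 1 to compound 2 (1.00 log units; beyond the scatter).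

The compounds shown leave open how far beyond the limit compound 3 and compound 4 truly lie, so the two cores cannot be ranked for this replacement. They also leave open how a bromo group on that aromatic carbon, or an ethyl group in place of the methyl on the sulfamoyl nitrogen, would behave in this assay.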